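A few compounds are considered here, and "the series" means these few. Any claim that something is new, unique, unknown or untested is made for them only; others in the source may bear on it.

Compound 1, `CCC1=C(C(N)=O)C(c2ccc(F)cc2F)N(C(=O)NCCCN2CCN(c3ccccc3C(N)=O)CC2)C(=O)N1`: 720 nM
Compound 2, `COC(=O)C1=C(C)NC(=O)N(C(=O)NCCCN2CCN(c3ccc(Cl)cc3)CC2)C1c1ccc(F)c(F)c1`: 17 nM

Of the compounds shown here, two have been measured in an assay on liver for binding affinity to Alpha-1B adrenergic receptor (Homo sapiens), using microsomes; on this read-out higher numbers stand for weaker inhibition and lower numbers for stronger inhibition. In this assay compound 1 gives 720 nM, while compound 2 gives 17 nM. Compound 2 therefore stands at the lowest number of the two, and the gap up to compound 1 lies well beyond the usual scatter; the two structures differ in several places at once, so no single change can be credited for this gap.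

Compound 3, `COC(=O)C1=C(C)NC(=O)N(C(=O)NCCCN2CCN(c3cccc(Cl)c3)CC2)C1c1ccc(F)c(F)c1`, is not yet measured. It keeps the whole of compound 2 except for one change: 3-chlorophenyl in place of 4-chlorophenyl on an amine nitrogen in a ring. Within the data shown here, no measured pair shows what moving the chlorine on this ring does here, so no step is known for it. The expected step from compound 2 to compound 3 is a 1.8-fold higher number from compound 2 to compound 3 (0.25 log units; within the scatter), a modest move toward a higher number that may still fall within the scatter. Compound 3 is estimated at 30 nM, with a likely range from 8 nM to 120 nM.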

Compound 3, inhibition constant: 8.4 nM
Compound 3: middle estimate off by 3.6-fold (0.55 log units), on the high side; low and high end bracket the measured number.
By their numbers in this assay, from the lowest: compound 3; then compound 2; then compound 1.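

In this assay, replacing 4-chlorophenyl with 3-chlorophenyl on the amine nitrogen in the ring gives a 2.0-fold lower number from compound 2 to compound 3 (0.31 log units; beyond the scatter), a modest step toward stronger inhibition. Among these compounds, because only the place of the chlorine changes while the atoms stay the same, this pair shows for the first time that the number at this position responds to the arrangement of the ring alone, which the broader gap involving compound 1 could not show. The compounds offer no measurement that accounts for this step.

Still open, going by these compounds, is whether a bromine, a methoxy group or a plain phenyl ring would give a lower or higher number than the chlorine in compound 3. It is also unknown whether a longer chain to the shared core would keep this step.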